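Swapping an amino for chloro on a purine-like core

A few compounds are considered here, and "the series" means these few. Any claim that something is new, unique, unknown or untested is made for them only; others in the source may bear on it.

Three compounds with a shared fused core and a chloromethyl-bearing benzyl arm have been tested in a functional assay on M14 cells (Homo sapiens) for cytotoxicity, read by sulforhodamine B assay, with a stated time of 48 h; on this read-out lower numbers stand for stronger inhibition of growth and higher numbers for weaker inhibition of growth. Compound 1 `ClCc1ccc(Cn2cnc3c(Cl)ncnc32)cc1` gives 1280 nM. Compound 3 `ClCc1ccccc1Cn1cnc2ncnc(Cl)c21` gives 1900 nM. Within the data shown here, compound 2 `Nc1nc(Cl)c2ncn(Cc3ccc(CCl)cc3)c2n1` gives 14100 nM, the highest of the three numbers, and its only single-change neighbour is compound 1: the step of an 11-fold higher number from compound 1 to compound 2 (1.04 log units; beyond the scatter) is large. Compound 4 `ClCc1ccc(Cn2cnc3c(Cl)nc(Cl)nc32)cc1` differs from compound 2 by chloro in place of amino on an aromatic carbon. Among the measured compounds shown here, the one step that bears on this position shows that adding amino raised the number sharply; removing it for chloro is expected to undo much of that, so a clear drop a 5.6-fold lower number from compound 2 to compound 4 (0.75 log units; beyond the scatter) is expected. Compound 4 is therefore estimated at 2500 nM, most likely between 800 nM and 8000 nM.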

Compound 4, concentration for 50% growth inhibition: 10700 nM
Compound 4: middle estimate off by 4.3-fold (0.63 log units), on the low side; measured number above the stated range.
By their numbers in this assay, from the lowest: compounds 1 and 3 (each within the scatter of the next); then compounds 4 and 2 (each within the scatter of the next).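

At this position, the amino and chloro groups cannot be told apart: a 1.3-fold lower number from compound 2 to compound 4 (0.12 log units; within the scatter). Chloro in place of hydrogen gives an 8.4-fold higher number from compound 1 to compound 4 (0.92 log units; beyond the scatter), so the weaker growth inhibition seen with amino also appears with chloro and is not particular to amino. Nothing measured here says why the two groups match.

On these data alone, whether other groups at this position, such as methyl or methoxy, also raise the number stays open. So does whether the same step holds with the arm of compound 3.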